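The compounds below may be only part of what the source reports. "The series", "measured", "known", "first", "only" and "open" are said of these compounds alone.

Measured so far in an assay on cells for inhibition of Voltage-dependent T-type calcium channel subunit alpha-1H (Homo sapiens), read by FLIPR and calcium flux, with stated times of 600 s and 300 s; a higher number here means a weaker inhibitor, a lower number a stronger inhibitor:
compound 1 `N=C(N)NCCCOc1ccc(CNc2nc3ccc(Oc4cccc(C(F)(F)F)c4)cc3s2)cc1` gives 270000 nM
compound 2 `CN(Cc1ccc(OCCCN)cc1)c1nc2ccc(Oc3cccc(C(F)(F)F)c3)cc2s1` gives 239000 nM
compound 3 `N=C(N)NCCCOc1ccc(CNc2nc3ccc(Oc4ccc(O)cc4)cc3s2)cc1` gives 319000 nM

Compounds 1 and 3 share one core and differ in a single place: 4-hydroxyphenyl in place of 3-(trifluoromethyl)phenyl on an oxygen on an aromatic ring. In this assay this change made a step of a 1.2-fold higher number from compound 1 to compound 3 (0.07 log units; within the scatter). Compound 2 carries a different core; the difference between the cores of compound 1 and compound 2 is not broken down here. The values of compound 1 and compound 2 in this assay lie within the scatter of each other, as do those of compound 2 and compound 3.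

Compound 4 `CN(Cc1ccc(OCCCN)cc1)c1nc2ccc(Oc3ccc(O)cc3)cc2s1` has not been measured. It differs from compound 2 by 4-hydroxyphenyl in place of 3-(trifluoromethyl)phenyl on an oxygen on an aromatic ring, the same change as from compound 1 to compound 3, made at the same place. The step expected for compound 4 in this assay is a 1.2-fold higher number from compound 2 to compound 4 (0.07 log units; within the scatter), resting on the step of a 1.2-fold higher number from compound 1 to compound 3 (0.07 log units; within the scatter) having stayed within the scatter. Compound 4 is therefore estimated at 280000 nM in this assay, with a likely range from 150000 nM to 520000 nM.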

Compound 4, half-maximal inhibitory concentration: 165000 nM
For compound 4 the middle estimate is 1.7-fold (0.23 log units) above the measured one; the measured number falls inside the stated range.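

In this assay, 4-hydroxyphenyl in place of 3-(trifluoromethyl)phenyl on an oxygen on an aromatic ring gives a 1.4-fold lower number from compound 2 to compound 4 (0.16 log units; within the scatter). Set beside the earlier step on the core of compound 1, the new step shows no detectable difference between the two cores: the same change on two cores in this assay, a 1.2-fold higher number (0.07 log units; within the scatter) from compound 1 to compound 3 and a 1.4-fold lower number (0.16 log units; within the scatter) from compound 2 to compound 4, 1.7-fold (0.23 log units) apart, within the scatter of two such steps. Within the data shown here, this shows only that the change stayed within the scatter on both cores, so the two pairs give no sign that the core alters its outcome; they do not show a shared effect of any measurable size or direction, and with no step beyond the scatter, they do not test whether a real effect would carry from one core to the other.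

Open, from the compounds shown here alone, is whether a different group on that oxygen, such as a phenyl ring carrying a nitrile or a carboxylic acid, would give a step beyond the scatter on either core. Also open, going by these compounds, is whether a longer chain ending in the amine of compound 2 would do so.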